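Selenium-heterocycle antiproliferative series: methoxy for methyl step

The compounds below may be only part of what the source reports. "The series", "measured", "known", "first", "only" and "open" are said of these compounds alone.

Measured compounds:
- Compound 1 `O=c1c2ccccc2[se]n1-c1nnc(-c2ccc(Br)cc2)s1`: 43300 nM
- Compound 2 `O=c1c2ccccc2[se]n1-c1nnc(-c2ccc(F)cc2)s1`: 61500 nM
- Compound 3 `Cc1ccccc1-c1nnc(-n2[se]c3ccccc3c2=O)s1`: 36800 nM

All three share the same core and differ only on the pendant aryl ring. In a functional assay on MCF7 cells (Homo sapiens) for antiproliferative activity, read by CCK-8 assay, with a stated time of 48 h (on this read-out lower numbers stand for stronger inhibition and higher numbers for weaker inhibition), compound 1 gives 43300 nM, compound 2 gives 61500 nM and compound 3 gives 36800 nM. Every step measured so far is small: a 1.4-fold higher number from compound 1 to compound 2 (0.15 log units; within the scatter), a 1.2-fold lower number from compound 1 to compound 3 (0.07 log units; within the scatter) and a 1.7-fold lower number from compound 2 to compound 3 (0.22 log units; within the scatter). Compound 3 carries the lowest number of the three, but its gaps to compound 1 and compound 2 are both within the scatter, so no ordering can be read from them.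

Compound 4 `COc1ccccc1-c1nnc(-n2[se]c3ccccc3c2=O)s1` is the next step from compound 3, the change being (methoxy in place of methyl on an aromatic carbon). Going by the values given here, no measured step involves a methoxy or exchanges one group for another at this same place on the ring, so nothing bears on it directly. What the three measured steps do show is that exchanging substituents on this aryl ring, whether bromo, fluoro or 2-methyl, has left this assay unchanged beyond the scatter. The expectation is therefore a step of a 1.0-fold lower number from compound 3 to compound 4 (0.01 log units; within the scatter), with no direction favoured.

Compound 4 is estimated at 36000 nM, with a range from 17000 nM to 75000 nM.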

Compound 4, half-maximal inhibitory concentration: 3920 nM
The estimate for compound 4 lay 9.2-fold (0.96 log units) above the measured number, outside the stated range (below it).
By their numbers in this assay, from the lowest: compound 4; then compounds 3, 1 and 2 (each within the scatter of the next).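

In this assay, going by these compounds alone, methoxy in place of methyl gives a 9.4-fold lower number from compound 3 to compound 4 (0.97 log units; beyond the scatter), the first step to lie beyond the scatter. This place on the aryl ring, ortho to a large group, therefore responds to a substituent exchange, which the comparisons among the 4-bromophenyl, 4-fluorophenyl and 2-methylphenyl compounds did not reveal. The exchange adds one carbon and one oxygen-bearing hydrogen-bond acceptor in place of the methyl, but nothing available accounts for the size of the step or links it to either feature.

As far as these compounds go, whether the oxygen or the larger group drives the step remains open, and a hydroxyl, an ethoxy or an amine at this same place would help separate those readings. From the compounds shown here alone, it is also open whether a methoxy group would produce a step of similar size on the 4-bromophenyl or 4-fluorophenyl rings, so the result currently rests on a single pair, compound 3 and compound 4.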